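Carbamate Homologues Compared for Metabolic Stability

The source may hold more compounds than are shown below. What is called first, only, known or untested is meant among the compounds shown, and "the series" means these compounds.

Compound 1 `CCCCCCCNC(=O)Oc1ccc(Cl)cc1C(=O)Nc1cccc(Cl)c1` gives 64 h in an ADME assay for metabolic stability, read by HPLC, at pH 7; on this read-out lower numbers stand for a shorter-lived compound and higher numbers for a longer-lived compound.
Compound 2 `CCCCCCCCNC(=O)Oc1ccc(Cl)cc1C(=O)Nc1cccc(Cl)c1` gives 64 h.
Compound 3 `CCCCCCCNC(=O)Oc1ccc(Cl)cc1C(=O)Nc1ccc(Cl)c(Cl)c1` gives 64 h.

Compound 4 `CCCCCCCCNC(=O)Oc1ccc(Cl)cc1C(=O)Nc1ccc(Cl)c(Cl)c1` has not yet been measured. It differs from compound 3 by methyl in place of hydrogen on a saturated chain carbon, seven bonds along the chain from an amide-type nitrogen. The same change has already been made once among these compounds, from compound 1 to compound 2, where it reads (methyl in place of hydrogen on a saturated chain carbon, seven bonds along the chain from an amide-type nitrogen); the two place descriptions are identical word for word, so this is the same change, and its step was no change at the digits printed from compound 1 to compound 2 (within the scatter). The core of compound 3 differs from that of compound 1 by chloro in place of hydrogen on an aromatic carbon, a step that gave no change at the digits printed from compound 1 to compound 3 (within the scatter). Compound 3 thus stands level with compound 1 and compound 2. For compound 4 the step is expected to be no change at the digits printed from compound 3 to compound 4 (within the scatter) in this assay, because the same change earlier gave no change at the digits printed from compound 1 to compound 2 (within the scatter). Compound 4 is therefore estimated at 64 h, with a range from 32 h to 128 h.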

Compound 4, half-life: 64 h
Beside the measured number, compound 4's estimate shows no gap at the digits printed; the measured number falls inside the stated range.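

In this assay, methyl in place of hydrogen on a saturated chain carbon gave no change at the digits printed from compound 3 to compound 4 (within the scatter), and chloro in place of hydrogen on an aromatic carbon gave no change at the digits printed from compound 2 to compound 4 (within the scatter). The chain change carried over to the second core with no difference between its two steps: the same change on two cores in this assay, no change at the digits printed (within the scatter) from compound 1 to compound 2 and no change at the digits printed (within the scatter) from compound 3 to compound 4, 1.0-fold (0.00 log units) apart, within the scatter of two such steps The chloro change behaved the same way, but this shows only that these two changes stayed without a visible step on these cores, not that a change with a larger step would carry over as well: the same change on two cores in this assay, no change at the digits printed (within the scatter) from compound 1 to compound 3 and no change at the digits printed (within the scatter) from compound 2 to compound 4, 1.0-fold (0.00 log units) apart, within the scatter of two such steps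

The compounds shown leave open whether a longer chain, or an amine at the end of the chain, would shift the half-life. They also leave open what a carboxylic acid or a nitrile in place of the chloro would do.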